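Swapping Methyl for Cyano: Expected Effect on Cytotoxicity

This account rests on a few compounds, and the source may have more. Where it says the series, first, only, none or still open, it means among the compounds named here.

Compound 1 `COc1ccc(CN(C(=O)Nc2ccc(C#N)cc2)n2cnnc2)cc1OC`: > 50000 nM
Compound 2 `COc1cc(CN(C(=O)Nc2ccc(C)cc2)n2cnnc2)cc(OC)c1OC`: 22800 nM

In a functional assay on A549 cells (Homo sapiens) for cytotoxicity, read by MTT assay, with a stated time of 48 h (on this read-out lower numbers stand for stronger inhibition and higher numbers for weaker inhibition), compound 1 reaches only a limit, > 50000 nM. Compound 2 gives 22800 nM, the only plain number shown. The other entry is the limit of > 50000 nM in this assay, at which 1 of the 2 values shown sits. Compound 3 `COc1cc(CN(C(=O)Nc2ccc(C#N)cc2)n2cnnc2)cc(OC)c1OC` differs from compound 2 by cyano in place of methyl on an aromatic carbon. Among the measured compounds shown here, no measured pair covers this change directly. Compound 1 also carries cyano and only reaches the limit > 50000 nM. Compound 3 is therefore expected to come out weaker, by a step of a 2.0-fold higher number from compound 2 to compound 3 (0.30 log units; within the scatter) beyond the scatter. Compound 3 is estimated at 45000 nM, within 15000 nM to 120000 nM.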

Compound 3, half-maximal inhibitory concentration: 20700 nM
Compound 3: the middle estimate sits 2.2-fold (0.34 log units) above what was measured; the measured number falls inside the stated range.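

Swapping methyl for cyano at this position makes no clear difference in this assay, with a 1.1-fold lower number from compound 2 to compound 3 (0.04 log units; within the scatter), so cyano by itself does not bring the weak reading seen for compound 1. With cyano kept in place, methoxy in place of hydrogen on an aromatic carbon gives an at least 2.4-fold lower number from compound 1 to compound 3 (0.38 log units; beyond the scatter). Compound 1 is read only as a limit, so the true size of this step remains unknown: the limit of > 50000 nM in this assay, at which 1 of the 3 values shown sits.

From the compounds shown here alone, whether an amine or a carboxylic acid at this position would move the reading remains open. The compounds shown also leave open whether the methoxy step would hold with methyl in place of cyano.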